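This account rests on a few compounds, and the source may have more. Where it says the series, first, only, none or still open, it means among the compounds named here.

Measured compounds:
- compound 1, `COc1cc2nc(N3CCC(OCC(C)OC)CC3)nc(N)c2cc1OC`, 1.41 nM
- compound 2, `CCOCC(OC1CCN(c2nc(N)c3cc(OC)c(OC)cc3n2)CC1)c1ccccc1`, 10 nM
- compound 3, `CCOC(COC1CCN(c2nc(N)c3cc(OC)c(OC)cc3n2)CC1)c1ccccc1`, 0.52 nM

All three compounds share the same core and differ only in the side chain on the oxygen of the saturated ring. In an assay on brain for displacement of a labelled ligand from Adrenergic receptor alpha-1 (Rattus norvegicus) (on this read-out higher numbers stand for weaker inhibition and lower numbers for stronger inhibition), compound 1 stands second highest of the three numbers: the nearest is compound 3 with a 2.7-fold lower number from compound 1 to compound 3 (0.43 log units; beyond the scatter), and the furthest is compound 2 with a 7.1-fold higher number from compound 1 to compound 2 (0.85 log units; beyond the scatter). Between those two, a 19-fold lower number from compound 2 to compound 3 (1.28 log units; beyond the scatter), so where the phenyl ring is placed on the chain matters a great deal here.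

Compound 4, `COc1cc2nc(N3CCC(OCC(C)(O)c4ccccc4)CC3)nc(N)c2cc1OC`, has not yet been measured. Compared with compound 1 it carries 1-hydroxy-1-phenylethyl in place of 1-methoxyethyl on a saturated chain carbon bound to an oxygen on a saturated carbon. Two of the known steps bear on this. Compound 3 shows that adding a phenyl ring at the chain carbon bound to the ring oxygen can lower the number, a modest step. Compound 2 shows that a phenyl ring one carbon away raises it. For the measured compounds named here, compound 4 places the phenyl as in compound 3, but the ether oxygen becomes a hydroxyl and a methyl is kept; no measured pair covers that exchange. A modest step downward is therefore expected, with real uncertainty in direction: compound 4 is estimated at 1 nM, within 0.3 nM to 4 nM, meaning a 1.4-fold lower number from compound 1 to compound 4 (0.15 log units; within the scatter).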

Compound 4, inhibition constant: 0.62 nM
For compound 4 the middle estimate is 1.6-fold (0.21 log units) above the measured one; the range from low to high includes it.
By their numbers in this assay, from the lowest: compounds 3 and 4 (each within the scatter of the next); then compound 1; then compound 2.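

In this assay, placing 1-hydroxy-1-phenylethyl in place of 1-methoxyethyl, on a saturated chain carbon bound to an oxygen on a saturated carbon, gives a 2.3-fold lower number from compound 1 to compound 4 (0.36 log units; beyond the scatter), so this place tolerates a phenyl ring arriving together with a hydrogen-bond donor, and binding does not weaken. The ether of the earlier phenyl compound is not needed to hold the low number: the change from ethoxy(phenyl)methyl to 1-hydroxy-1-phenylethyl gives a 1.2-fold higher number from compound 3 to compound 4 (0.08 log units; within the scatter), and these two groups cannot be told apart in this assay. The step of a 16-fold lower number from compound 2 to compound 4 (1.21 log units; beyond the scatter) now sets two chains, those of compound 3 and compound 4, with the phenyl ring on the outer chain carbon against the 2-ethoxy-1-phenylethyl chain, which goes against any idea that a phenyl ring on this chain is enough by itself for a low number.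

Nothing among the data shown explains why these steps take the sizes they do. How an amine in place of the hydroxyl, or a longer chain in place of the methyl, would read here is open, and so is the share of the phenyl ring and of the hydroxyl, which compound 4 brings in at once.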